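A few compounds are considered here, and "the series" means these few. Any claim that something is new, unique, unknown or untested is made for them only; others in the source may bear on it.

Three compounds have so far been run in a functional assay on HT-29 cells (Homo sapiens) for cytotoxicity, read by MTT assay, with a stated time of 72 h; on this read-out higher numbers stand for weaker inhibition and lower numbers for stronger inhibition. Compound 1 `COc1ccc(-c2cc(C(=O)Nc3ccc(Oc4ccnc5cc(OCCCN6CCCCC6)c(OC)cc45)c(F)c3)c3ccccc3n2)cc1` gives 690 nM. Compound 2 `COc1cc2c(Oc3ccc(NC(=O)c4cc(-c5cccc(Cl)c5)nc5ccccc45)cc3F)ccnc2cc1OCCCN1CCCCC1` gives 62 nM. Compound 3 `COc1cc2c(Oc3ccc(NC(=O)c4cc(-c5cccc(Cl)c5)nc5ccc(F)cc45)cc3F)ccnc2cc1OCCCN1CCCC1` gives 670 nM; its nearest neighbour on this read-out is compound 1, and the two values lie within the scatter of each other. Compound 2 and compound 1 differ in one place, (4-methoxyphenyl in place of 3-chlorophenyl on an aromatic carbon), and that change produces an 11-fold higher number from compound 2 to compound 1 (1.05 log units; beyond the scatter). The difference between the core of compound 2 and the core of compound 3 is not broken down here. Compound 4 `COc1ccc(-c2cc(C(=O)Nc3ccc(Oc4ccnc5cc(OCCCN6CCCC6)c(OC)cc45)c(F)c3)c3cc(F)ccc3n2)cc1` has not yet been measured in this assay; it stands to compound 3 as compound 1 stands to compound 2, through (4-methoxyphenyl in place of 3-chlorophenyl on an aromatic carbon), the same change at the same place. Among the compounds with values here, only one instance of this change has been measured, so any expectation rests on a single step. The expected step is a 9.0-fold higher number from compound 3 to compound 4 (0.95 log units; beyond the scatter), because the same change gave an 11-fold higher number from compound 2 to compound 1 (1.05 log units; beyond the scatter). Compound 4 is therefore estimated at 6000 nM in this assay, with a likely range from 2000 nM to 20000 nM.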

Compound 4, half-maximal inhibitory concentration: 610 nM
The estimate for compound 4 lay 9.8-fold (0.99 log units) above the measured number; the whole stated range lies above it.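

In this assay, placing 4-methoxyphenyl where 3-chlorophenyl stood gives a 1.1-fold lower number from compound 3 to compound 4 (0.04 log units; within the scatter), so the change does not carry from one core to the other as a fixed step: the same change on two cores in this assay, an 11-fold higher number (1.05 log units; beyond the scatter) from compound 2 to compound 1 and a 1.1-fold lower number (0.04 log units; within the scatter) from compound 3 to compound 4, 12-fold (1.09 log units) apart, beyond the scatter of two such steps

On the core of compound 3, the two groups cannot be told apart on this read-out, whereas on the core of compound 2 the 3-chlorophenyl compound, compound 2, gives the lower number. This shows that the size of the step depends on the core, but it does not show which of the differences between the two cores is responsible, and two pairs set no rule for any further core.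

From the compounds shown here alone, it remains open which of the two steps is the more typical for this change across the series. Also open, going by these compounds, is how an unsubstituted phenyl or an amine-bearing phenyl on the same aromatic carbon would read on each of these two cores.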